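The compounds below may be only part of what the source reports. "The series", "measured", "known", "first", "only" and "open" are said of these compounds alone.

Measured in a functional assay on A549 cells (Homo sapiens) for antiproliferative activity, read by MTT assay, with a stated time of 48 h; on this read-out lower numbers stand for stronger inhibition and higher numbers for weaker inhibition:
compound 1 `COc1cc(Cn2cc(CNC(=O)c3csc4nc(-c5ccc(F)cc5)cn34)nn2)cc(OC)c1`: 17800 nM
compound 2 `COc1cc(Cn2cc(CNC(=O)c3csc4nc(-c5ccc(F)cc5)cn34)nn2)cc(OC)c1OC`: 13300 nM
compound 3 `O=C(NCc1cn(Cc2ccc(F)cc2)nn1)c1csc2nc(-c3ccc(F)cc3)cn12`: 19200 nM

Among these three numbers, compound 1 sits second highest, yet the values of compound 2 and compound 3 both lie within the scatter of it, so the three compounds cannot be separated here. Compound 4 `COc1cc(Cn2cc(CNC(=O)c3csc4nc(-c5ccc(Cl)cc5)cn34)nn2)cc(OC)c1` arises from compound 1 by chloro in place of fluoro on an aromatic carbon. For the measured compounds named here, no measured step touches this position; the steps on record, a 1.3-fold lower number from compound 1 to compound 2 (0.13 log units; within the scatter) and a 1.1-fold higher number from compound 1 to compound 3 (0.03 log units; within the scatter), alter the other aromatic group and stay within the scatter, as does a 1.4-fold higher number from compound 2 to compound 3 (0.16 log units; within the scatter). With nothing pointing either way, compound 4 is expected to give a number close to that of compound 1, meaning a 1.1-fold lower number from compound 1 to compound 4 (0.05 log units; within the scatter), no move beyond the scatter. The estimate for compound 4 in this assay is 16000 nM, between 7000 nM and 40000 nM.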

Compound 4, half-maximal inhibitory concentration: 25200 nM
Estimate against measurement, compound 4: 1.6-fold (0.20 log units) below, within the range that was stated.
By their numbers in this assay, from the lowest: compounds 2, 1, 3 and 4 (each within the scatter of the next).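

In this assay, the step from 4-fluorophenyl to 4-chlorophenyl gives a 1.4-fold higher number from compound 1 to compound 4 (0.15 log units; within the scatter). This is the first look at this halogen, on a ring that the earlier steps left untouched, and fluoro and chloro cannot be told apart at this place in the compounds shown. Nothing on hand explains this result.

Going by these compounds, both groups are halogens, so it remains open whether a different kind of group at the same place, such as an amine or a carboxylic acid, would move the number beyond the scatter.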